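Lengthening the chain of compound 3 to compound 4

The source may hold more compounds than are shown below. What is called first, only, known or untested is meant among the compounds shown, and "the series" means these compounds.

In a functional assay on HBL-100 cells (Homo sapiens) for antiproliferative activity, read by sulforhodamine B assay, with a stated time of 48 h (a lower number here means a stronger inhibitor of growth, a higher number a weaker inhibitor of growth), compound 1 `CCCCCCCCCCCCCCC[C@@H](O)[C@@H](N)[C@@H](C)O` gives 21000 nM, compound 2 `CCCCCCCCCCCCCCC[C@@H](O)[C@@H](N)C(C)C` gives 4900 nM and compound 3 `CCCCCCCCC[C@@H](O)[C@@H](N)[C@@H](C)CC` gives 13000 nM. Compound 3 lies within the scatter of compound 1 and beyond it from compound 2, on the higher side. Compound 4 `CCCCCCCCCCCCCCC[C@@H](O)[C@@H](N)[C@@H](C)CC` differs from compound 3 by one change: hexyl in place of hydrogen on a saturated chain carbon, ten or more bonds along the chain from an oxygen on a saturated carbon. Within the data shown here, no measured step covers a change of chain length. Among the measured compounds shown here, the only step, a 4.3-fold lower number from compound 1 to compound 2 (0.63 log units; beyond the scatter), is modest and puts isopropyl in place of 1-hydroxyethyl. Compound 4 shares its chain length with compound 2, which gives 4900 nM, so a modestly lower number is expected. The expected move is a 2.2-fold lower number from compound 3 to compound 4 (0.34 log units; beyond the scatter). For compound 4 the estimate is 6000 nM, with an expected range of 2500 nM to 15000 nM.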

Compound 4, concentration for 50% growth inhibition: 2400 nM
The estimate for compound 4 lay 2.5-fold (0.40 log units) above the measured number, outside the stated range (below it).
By their numbers in this assay, from the lowest: compound 4; then compound 2; then compounds 3 and 1 (each within the scatter of the next).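

In this assay, among these compounds, hexyl in place of hydrogen gives a 5.4-fold lower number from compound 3 to compound 4 (0.73 log units; beyond the scatter), the only step on chain length so far, and it lies beyond the scatter. With the chain held, methyl in place of hydrogen three bonds along the chain from an amine nitrogen gives a 2.0-fold lower number from compound 2 to compound 4 (0.31 log units; beyond the scatter), and ethyl in place of hydroxy gives an 8.8-fold lower number from compound 1 to compound 4 (0.94 log units; beyond the scatter), so both of these single changes also count. Nothing available explains any of these steps. Open, on these data alone, is how a longer chain than that of compound 4 would read, and how a carboxylic acid in place of the amine would read.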